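A few compounds are considered here, and "the series" means these few. Any claim that something is new, unique, unknown or untested is made for them only; others in the source may bear on it.

Compound 3, `CC(=O)N1CCC(CN(C2Cc3cc(C#N)ccc3N(Cc3cncn3C)C2)S(=O)(=O)c2ccccn2)CC1`, in an ADME assay on Caco-2 cells (Homo sapiens) for permeability, in the apical to basolateral direction (on this read-out lower numbers stand for lower permeability and higher numbers for higher permeability), gives 0.5 10^-6 cm/s. Compound 1, `CCCC(=O)N1CCC(CN(C2Cc3cc(C#N)ccc3N(Cc3cncn3C)C2)S(=O)(=O)c2ccccn2)CC1`, gives 0.5 10^-6 cm/s, the same number at the digits shown, so that the two stand level; compound 2, `Cn1cncc1CN1CC(N(CC2CCN(C(=O)N3CCCCC3)CC2)S(=O)(=O)c2ccccn2)Cc2cc(C#N)ccc21`, gives 0.6 10^-6 cm/s, and a 1.2-fold lower number from compound 2 to compound 3 (0.08 log units; within the scatter) lies within the scatter, as does a 1.2-fold higher number from compound 1 to compound 2 (0.08 log units; within the scatter). Compound 4, `Cn1cncc1CN1CC(N(CC2CCN(C(=O)c3ccccc3)CC2)S(=O)(=O)c2ccccn2)Cc2cc(C#N)ccc21`, differs from compound 3 in one place: phenyl in place of methyl on a carbonyl carbon. The measured steps that bear on this change are those that alter the group on the same carbonyl carbon or on the saturated chain carbon bound to it. no change at the digits printed from compound 1 to compound 3 (within the scatter) and a 1.2-fold lower number from compound 2 to compound 3 (0.08 log units; within the scatter) both sit within the scatter, so the three acyl groups tried so far, with the ring of piperidin-1-yl among them, leave this read-out where it was. On that basis no step beyond the scatter is expected in this assay, and the step of no change at the digits printed from compound 3 to compound 4 (within the scatter) is estimated to stay within it. Compound 4 is therefore expected to give about 0.5 10^-6 cm/s, with a range from 0.3 10^-6 cm/s to 1 10^-6 cm/s.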

Compound 4, apparent permeability: 0.5 10^-6 cm/s
The estimate for compound 4 equals the measured number at the digits printed; low and high end bracket the measured number.
By their numbers in this assay, from the lowest: compounds 1, 3, 4 and 2 (each within the scatter of the next).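

With phenyl on the carbonyl carbon, whose other neighbour is an amide-type nitrogen in a ring, this position now carries a six-membered aromatic ring of carbon only, and in this assay the number stays within the scatter of every earlier compound (no change at the digits printed from compound 3 to compound 4 (within the scatter); no change at the digits printed from compound 1 to compound 4 (within the scatter); a 1.2-fold lower number from compound 2 to compound 4 (0.08 log units; within the scatter)). The change from acetyl to benzoyl therefore adds an aromatic ring to the groups tried here, and this read-out does not separate it from methyl, propyl or piperidin-1-yl. No measurement shown accounts for this lack of separation.

From the compounds shown here alone, whether an aminomethyl group or a carboxylic acid in place of phenyl on this carbonyl carbon would give a step beyond the scatter remains open. Every step shown lies at this one carbonyl carbon, so the effect of changes elsewhere on the shared core also remains open.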